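Moving the chloro on the pyridinyl amide of compound 3

The source may report more compounds than this note shows. Statements on the series, on what has been measured and on what is new or still open speak of the compounds shown alone.

Compounds measured so far:
- compound 1, `Cn1cc(-c2cnc(N)c(Oc3ccc(C(=O)Nc4ccccc4)cc3)n2)cn1`: 9210 nM
- compound 2, `Cn1cc(-c2cnc(N)c(Oc3ccc(C(=O)Nc4ccccc4Cl)cc3)n2)cn1`: 41400 nM
- compound 3, `Cn1cc(-c2cnc(N)c(Oc3ccc(C(=O)Nc4cccc(Cl)n4)cc3)n2)cn1`: 48600 nM

In a functional assay on LoVo cells (Homo sapiens) for inhibition, read by MTT assay, with a stated time of 72 h (on this read-out lower numbers stand for stronger inhibition and higher numbers for weaker inhibition), compound 3 gives the highest number of the three. Compound 2 sits within the scatter of it, while compound 1 gives a clearly lower number, as the step of a 5.3-fold higher number from compound 1 to compound 3 (0.72 log units; beyond the scatter) shows. The unmeasured compound 4, `Cn1cc(-c2cnc(N)c(Oc3ccc(C(=O)Nc4ccc(Cl)cn4)cc3)n2)cn1`, differs from compound 3 by a rearrangement only: 5-chloropyridin-2-yl in place of 6-chloropyridin-2-yl on an amide-type nitrogen.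

Within the data shown here, no measured step moves a substituent around the amide-bound ring, so the nearest evidence is indirect. The step of a 1.2-fold higher number from compound 2 to compound 3 (0.07 log units; within the scatter), which exchanged one chloro-bearing ring for another on the same nitrogen, stayed within the scatter, and the steps of a 4.5-fold higher number from compound 1 to compound 2 (0.65 log units; beyond the scatter) and a 5.3-fold higher number from compound 1 to compound 3 (0.72 log units; beyond the scatter) were both modest. Shifting the chloro within the pyridinyl ring is therefore expected to produce no step beyond the scatter in this assay, with perhaps a slight move toward a lower number given that compound 1 gives 9210 nM.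

Compound 4 is thus estimated at 32000 nM, within 11000 nM to 95000 nM. This estimate means a step of a 1.5-fold lower number from compound 3 to compound 4 (0.18 log units; within the scatter), which is expected to remain within the scatter.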

Compound 4, half-maximal inhibitory concentration: 6160 nM
Compound 4: middle estimate off by 5.2-fold (0.72 log units), on the high side, and the stated range ends above it.
By their numbers in this assay, from the lowest: compounds 4 and 1 (each within the scatter of the next); then compounds 2 and 3 (each within the scatter of the next).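

In this assay, among these compounds, the place of the chloro on the pyridinyl ring proves to matter: the rearrangement alone gives a 7.9-fold lower number from compound 3 to compound 4 (0.90 log units; beyond the scatter) and so separates two compounds with the same atoms, which no earlier step could show. The 5-chloropyridin-2-yl group also parts from the 2-chlorophenyl group, with a 6.7-fold lower number from compound 2 to compound 4 (0.83 log units; beyond the scatter) on the same amide-type nitrogen, while against phenyl it gives a 1.5-fold lower number from compound 1 to compound 4 (0.17 log units; within the scatter) and stays within the scatter, so a chloro-bearing ring here does not always go with a higher number. Nothing at hand explains why the two chloro positions differ.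

The compounds shown leave open whether a 5-fluoropyridin-2-yl or 5-methoxypyridin-2-yl group on this nitrogen would read like the 5-chloropyridin-2-yl group. With one cell read-out shown, they also leave open whether the same order would hold elsewhere.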